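The compounds below may be only part of what the source reports. "The series", "measured", "known", "first", "only" and "open" are said of these compounds alone.

Three compounds from a set built on one shared core have been measured in a physicochemical assay for solubility, read by spectrophotometry, in phosphate buffer, with a stated time of 2 h, at pH 7.4; on this read-out higher numbers stand for higher solubility and lower numbers for lower solubility. Compound 1, with the structure `COc1ccc2[nH]c(C(=O)N3CC(=O)N(Cc4ccccc4)[C@@H](CN4CCC5(CC4)CC5)C3)cc2c1`, gives 28200 nM in this assay. Compound 2, with the structure `COc1cccc(CN2C(=O)CN(C(=O)c3cc4cc(OC)ccc4[nH]3)C[C@@H]2Cc2ccccn2)c1`, gives 57900 nM, and compound 3, with the structure `COc1ccc2[nH]c(C(=O)N3CC(=O)N(Cc4ccccc4)[C@@H](N4CCC(Cc5ccccc5)CC4)C3)cc2c1`, gives 9300 nM. Among these three numbers compound 1 stands second highest: the value of compound 2 lies above it by a gap beyond the usual scatter, and the value of compound 3 lies below it by a larger gap, also beyond the scatter. For the measured compounds named here, none of these pairs differ in only one place, so no single-change step can be drawn between them.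

Compound 4, with the structure `COc1ccc2[nH]c(C(=O)N3CC(=O)N(Cc4ccccc4)[C@@H](CN4[C@H](C)COC[C@@H]4C)C3)cc2c1`, has not yet been measured in this assay. It differs from compound 1 at one place, where the 3,5-dimethylmorpholin-4-yl group takes the place of the earlier group: a group of 8 heavy atoms (6 carbon, 1 nitrogen, 1 oxygen; one six-membered non-aromatic ring with 2 hetero atoms) in place of a group of 8 heavy atoms (7 carbon, 1 nitrogen; one three-membered non-aromatic ring of carbon only, one six-membered non-aromatic ring with 1 hetero atom), on a saturated chain carbon bound to a saturated ring carbon

Going by the values given here, with no measured step of this kind available, the expectation rests on compound 1 alone. The step from compound 1 to compound 4 is expected to be a 2.0-fold higher number from compound 1 to compound 4 (0.29 log units; within the scatter), a modest rise in solubility that may or may not clear the scatter. Compound 4 is therefore estimated to give 55000 nM in this assay, within a range from 22000 nM to 140000 nM.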

Compound 4, solubility: > 100000 nM
Compound 4 gave a limit, no number; the forecaster's own chance of this, stated with the estimate: 5%; middle value at least 1.8-fold (0.25 log units) from the limit.
By their numbers in this assay, from the lowest: compound 3; then compound 1; then compound 2. At a limit, above all of these: compound 4.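

Compound 4 gives > 100000 nM in this assay, and this reading is a limit of the assay, not a number. The earlier compounds shown here offered no single-change step, whereas this pair isolates one change, on a saturated chain carbon bound to a saturated ring carbon: the 3,5-dimethylmorpholin-4-yl group takes the place of the group in compound 1, with the heavy-atom count unchanged but with oxygen in the ring and defined stereocentres added, and the result is an at least 3.5-fold higher number from compound 1 to compound 4 (0.54 log units; beyond the scatter). Going by these compounds, the step is bounded from one side only, and its full size stays unknown because the reading stops at the top of the range: the limit of > 100000 nM in this assay, at which 1 of the 4 values shown sits.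

The compounds shown cannot divide this rise among the ring oxygen, the methyl groups and the stereochemistry, since a plain morpholin-4-yl group and a 3,5-dimethylpiperidin-1-yl group do not appear among them at this place. On these data alone, whether the change would behave alike with a substituent other than the benzyl group of compound 1 and compound 4, or with a carboxylic acid or a longer chain at this place, also remains open.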